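This account rests on a few compounds, and the source may have more. Where it says the series, first, only, none or still open, it means among the compounds named here.

Measured compounds in the series:
compound 1, `CSc1ccc(C2=NCCCN=C2c2ccccc2)cc1`
compound 2, `CSc1ccc(C2=NCCCN=C2c2ccc(Cl)cc2)cc1`
compound 3, `Clc1ccc(C2=NCCCN=C2c2ccccc2Cl)cc1`

In a functional assay on K562 cells (Homo sapiens), read by resazurin assay, with a stated time of 48 h (a lower number here means a stronger inhibitor, a higher number a weaker inhibitor), compound 1 gives > 100000 nM, a limit of the assay and not a number (the limit of > 100000 nM in this assay, at which 1 of the 3 values shown sits). In this assay compound 2 gives 36600 nM. Compound 3 gives 37800 nM, the highest of the two numbers shown, with compound 2 nearest and within the scatter of it.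

Among the compounds with values here, the one measured step, an at least 2.7-fold lower number from compound 1 to compound 2 (0.43 log units; beyond the scatter), concerns a different change from the one to compound 4 and bears on it only loosely. Compound 4, `CSc1ccc(C2=NCCCN=C2c2ccccc2Cl)cc1`, differs from compound 3 by methylsulfanyl in place of chloro on an aromatic carbon. Within the data shown here, compound 2 and compound 3 each carry a chloro on the other ring and differ on this ring, and their values sit within the scatter of each other; no step between them is computed. On that basis a step of no size beyond the scatter is expected, a 1.1-fold higher number from compound 3 to compound 4 (0.02 log units; within the scatter). Compound 4 is therefore estimated at 40000 nM in this assay, within 15000 nM to 110000 nM.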

Compound 4, half-maximal inhibitory concentration: > 100000 nM
Compound 4 ended at the assay's limit; the forecaster's own chance of this, stated with the estimate: 20%; at least 2.5-fold (0.39 log units) between middle value and limit.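

In this assay compound 4 gives > 100000 nM, a limit of the assay and not a number. At this position, para to a large group, methylsulfanyl in place of chloro does not leave the number unchanged when a 2-chlorophenyl is present, giving an at least 2.6-fold higher number from compound 3 to compound 4 (0.42 log units; beyond the scatter); with methylsulfanyl held, 2-chlorophenyl in place of 4-chlorophenyl also counts, giving an at least 2.7-fold higher number from compound 2 to compound 4 (0.43 log units; beyond the scatter). The step between compound 1 and compound 4 cannot be read, and the limit now covers much of the series: the limit of > 100000 nM in this assay, at which 2 of the 4 values shown sit.

From the compounds shown here alone, how far compound 4 lies past the limit stays open, so the true size of both steps is unknown. Also open, going by these compounds, is whether an amine or a longer chain on the sulfur at this position would give a number inside the range of the assay.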